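Thiomorpholin-4-yl in place of 4-methylpiperazin-1-yl on compound 3

The source may hold more compounds than are shown below. What is called first, only, known or untested is meant among the compounds shown, and "the series" means these compounds.

In an ADME assay for metabolic stability, with a stated time of 0.5 h, at pH 1.2 (a higher number here means that more of the compound is left, a lower number that less of the compound is left), compound 1 `CC(=O)NC[C@H]1CN(c2ccc(-c3ccc(/C=N/N4CCN(C)CC4)nc3)c(F)c2)C(=O)O1` gives 98.3% and compound 2 `CC(=O)NC[C@H]1CN(c2ccc(-c3ccc(/C=N/N4CCSCC4)nc3)c(F)c2)C(=O)O1` gives 99.4% under the same conditions. Compound 3 `CC(=O)NC[C@H]1CN(c2ccc(-c3ccc(/C=N/N4CCN(C)CC4)c(O)c3)c(F)c2)C(=O)O1` gives 69.8% and holds the lowest of the three numbers, beyond the scatter from both others. Compound 4 `CC(=O)NC[C@H]1CN(c2ccc(-c3ccc(/C=N/N4CCSCC4)c(O)c3)c(F)c2)C(=O)O1` is still unmeasured, and the change that leads to it is thiomorpholin-4-yl in place of 4-methylpiperazin-1-yl on a double-bonded nitrogen with nothing else in the structure altered. Among the compounds with values here, the same exchange gave a number 1.1 percentage points higher from compound 1 to compound 2 (within the scatter) and is the only measured step that bears on it, although both of those values lie near the top of the range. No step beyond the scatter is therefore expected in this assay for this exchange. The estimated step is a number 1.2 percentage points higher from compound 3 to compound 4 (within the scatter) and stays within the scatter. For compound 4 the expected value is 71% with an estimated range from 59% to 83% around it.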

Compound 4, percent of the compound remaining: 96%
For compound 4 the middle estimate is 25 percentage points below the measured one; the measured number lies above the stated range.
By their numbers in this assay, from the lowest: compound 3; then compounds 4, 1 and 2 (each within the scatter of the next).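

On the core of compound 3, thiomorpholin-4-yl in place of 4-methylpiperazin-1-yl on a double-bonded nitrogen gives a real shift in this assay, with a number 26.2 percentage points higher from compound 3 to compound 4 (beyond the scatter). The earlier pair, with both numbers near the top of the range, could not show this. The size of the step therefore differs with the core: the same change on two cores in this assay, a number 1.1 percentage points higher (within the scatter) from compound 1 to compound 2 and a number 26.2 percentage points higher (beyond the scatter) from compound 3 to compound 4, 25.1 percentage points apart, beyond the scatter of two such steps

The compounds shown do not tell whether the sulfur of thiomorpholin-4-yl or the loss of the methyl-bearing nitrogen matters. From the compounds shown here alone, a morpholin-4-yl or piperidin-1-yl group in this place on the same core remains open.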